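This account rests on a few compounds, and the source may have more. Where it says the series, first, only, none or still open, it means among the compounds named here.

Working notes on the series. Going by the values given here, compound 3 `Cc1cc(C(=O)O)c(C)n1-c1cccc(Cl)c1` gives 430 nM in an assay on cells for inhibition of Palmitoleoyl-protein carboxylesterase NOTUM variant C330S (Homo sapiens), read by fluorescence, with a stated time of 40 min (on this read-out lower numbers stand for stronger inhibition and higher numbers for weaker inhibition), the lowest of the three numbers measured so far. Compound 1 `COc1c(Cl)cccc1-n1c(C)cc(C(=O)O)c1C` gives 800 nM in this assay, and the step of a 1.9-fold lower number from compound 1 to compound 3 (0.27 log units; within the scatter) stays within the scatter, so no order between compound 1 and compound 3 can be read. Compound 2 `Cc1cc(C(=O)O)c(C)n1-c1ccc(C(F)(F)F)c(Cl)c1` gives 1500 nM in this assay; the step of a 3.5-fold lower number from compound 2 to compound 3 (0.54 log units; beyond the scatter) is a modest gain.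

Compound 4 `Cc1cc(C(=O)O)c(C)n1-c1cccc(C#N)c1` has not yet been measured. It differs from compound 3 by cyano in place of chloro on an aromatic carbon. Neither measured step swaps one group for another on this ring; both remove a group and leave hydrogen. They indicate that changes on this ring have moved the number by modest amounts at most, the larger being a 3.5-fold lower number from compound 2 to compound 3 (0.54 log units; beyond the scatter). For compound 4 a step of comparable or smaller size is therefore expected in this assay, with no direction that the data can fix, estimated as a 1.4-fold higher number from compound 3 to compound 4 (0.14 log units; within the scatter). The estimate for compound 4 in this assay is 600 nM, with a range from 250 nM to 1500 nM.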

Compound 4, half-maximal inhibitory concentration: 3100 nM
Compound 4: the middle estimate sits 5.2-fold (0.71 log units) below what was measured; measured number outside the range, above it.
By their numbers in this assay, from the lowest: compounds 3, 1 and 2 (each within the scatter of the next, the first and the last beyond it); then compound 4.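

Going by these compounds alone, this is the first step that swaps one group for another on the aromatic ring rather than leaving hydrogen: a 7.2-fold higher number from compound 3 to compound 4 (0.86 log units; beyond the scatter) shows that in this assay the number at this place, meta to a large group, depends on which group sits there. Chloro and cyano are not interchangeable here, even though the earlier steps on this ring stayed modest or within the scatter. The cyano result therefore sets a limit on how freely this place can be changed, at least for this one pair. No measurement here bears on why the swap moves the number.

The compounds shown leave open how bromo or methyl at this same place would compare with chloro. They also leave open whether a carboxamide would track with cyano.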